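Series notes: the step from compound 3 to compound 4

The compounds below may be only part of what the source reports. "The series", "measured", "known", "first", "only" and "open" are said of these compounds alone.

Measured compounds in a functional assay on the whole organism for inhibition, with Rattus norvegicus as the target, read by paw edema, with stated times of 1 h and 3 h, at a dose of 50 mg/kg by the oral route; on this read-out higher numbers stand for more inhibition at the one dose given (going by the name of the read-out) and lower numbers for less inhibition:
Compound 1 `C/C(=N\OCC(=O)O)c1ccccc1Cl`: in this assay compound 1 gives < 20%, which is a limit of the assay and not a number.
Compound 2 `C/C(=N\OCC(=O)O)c1ccccc1C(=O)O`: in this assay compound 2 gives < 20%, likewise a limit of the assay.
Compound 3 `C/C(=N\OCC(=O)O)c1ccc(C)cc1`: in this assay compound 3 gives 20%.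

Within the data shown here, compound 3 therefore carries the only number in the set; the other two values are limits, so compound 3 cannot be placed in order against compound 1 or compound 2 beyond what a limit permits. Among the measured compounds shown here, the single step between measured compounds, a step that the two limits leave unreadable from compound 1 to compound 2, runs between two limits and its size is not readable. For the measured compounds named here, the only evidence on the measured values is the limit of < 20% in this assay, at which 2 of the 3 values shown sit.

Compound 4 `C/C(=N\OCC(=O)O)c1ccc(CC2CCCCC2)cc1` differs from compound 3 by cyclohexyl in place of hydrogen on a saturated chain carbon bound to an aromatic carbon. Going by the values given here, no measured pair carries this change or anything resembling it, so no measured step bears on it, and the expectation rests on the value of compound 3 alone. The step expected from compound 3 to compound 4 is a number 5 percentage points higher from compound 3 to compound 4 (within the scatter), within the scatter. Compound 4 is accordingly estimated at 25%, with a range from 8% to 50%.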

Compound 4, a percentage reported as inhibition, in the whole organism at one dose (the size of the read-out at that dose, not a potency): < 20%
Compound 4: a limit, no number; the forecaster's own chance of this, stated with the estimate: 35%; middle value at least 5 percentage points away from the limit.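

In this assay compound 4 gives < 20%, which is a limit of the assay and not a number. Cyclohexyl in place of hydrogen on a saturated chain carbon bound to an aromatic carbon gives a number no higher from compound 3 to compound 4 (the limit leaves the size open), so this large ring at this position brings no gain on the read-out over the plain methyl of compound 3, though the size of the step cannot be read. Compound 3 remains the only compound with a number, and the series now gathers at one limit: the limit of < 20% in this assay, at which 3 of the 4 values shown sit.

On these data alone, whether the read-out moves clear of that limit with a smaller change at this saturated chain carbon, such as a single extra ethyl chain carbon, remains open. As far as these compounds go, it is equally open whether an amine or a second carboxylic acid in the cyclohexyl's place would do so.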